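The source may hold more compounds than are shown below. What is called first, only, known or untested is meant among the compounds shown, and "the series" means these compounds.

Compound 1 `CC(C)(C)[C@@H](O)C(=O)N1C[C@@H]2C[C@@H]2[C@H]1C(=O)NCc1cc(Cl)ccc1-n1cnnn1` is a hydroxy-amide built on a fused bicyclic core; in a functional assay on a cell-free system (plasma, Homo sapiens), with a stated time of 3 min (a higher number here means a weaker inhibitor, a lower number a stronger inhibitor), compound 1 gives 570 nM. Compound 2 `CC(C)(C)C[C@@H](O)C(=O)N1C[C@@H]2C[C@@H]2[C@H]1C(=O)NCc1cc(Cl)ccc1-n1cnnn1` carries the change neopentyl in place of tert-butyl on a saturated chain carbon bound to a carbonyl carbon and an oxygen on a saturated carbon on that same core; in this assay compound 2 gives 910 nM. The step of a 1.6-fold higher number from compound 1 to compound 2 (0.20 log units; within the scatter) lies within the scatter, so the two values carry no order between them.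

Compound 3 `CC(C)(C)[C@@H](O)C(=O)N1[C@H](C(=O)NCc2cc(Cl)ccc2-n2cnnn2)C[C@@H]2C[C@@H]21` shares the tert-butyl group with compound 1 but has the same atoms joined differently in its core; the difference between the two cores is not broken down here. In this assay compound 3 gives 1500 nM, a number that is beyond the scatter from that of compound 1 and within the scatter of that of compound 2.

Compound 4 `CC(C)(C)C[C@@H](O)C(=O)N1[C@H](C(=O)NCc2cc(Cl)ccc2-n2cnnn2)C[C@@H]2C[C@@H]21` is the counterpart of compound 3 with the change (neopentyl in place of tert-butyl on a saturated chain carbon bound to a carbonyl carbon and an oxygen on a saturated carbon). This is the same change, at the same place, that takes compound 1 to compound 2, occurring twice among the four compounds. Among the measured compounds shown here, for compound 4 the step of a 1.6-fold higher number from compound 3 to compound 4 (0.20 log units; within the scatter) in this assay is expected to be close to the earlier step because the step of a 1.6-fold higher number from compound 1 to compound 2 (0.20 log units; within the scatter) was within the scatter and gives the only guide to the same change on the rearranged core. For the measured compounds named here, compound 4 is therefore estimated at 2400 nM in this assay, with a range from 1100 nM to 5000 nM reflecting that the single precedent is itself within the scatter.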

Compound 4, half-maximal inhibitory concentration: 570 nM
Beside the measured number, compound 4's estimate is 4.2-fold (0.62 log units) above it; measured number outside the range, below it.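

On the rearranged core, neopentyl in place of tert-butyl gives, in this assay, a 2.6-fold lower number from compound 3 to compound 4 (0.42 log units; beyond the scatter). Among the compounds shown here, the same change at the same place therefore does not carry over unchanged from the core of compound 1 to the core of compound 3, and the step on one core would have been a poor guide to the step on the other: the same change on two cores in this assay, a 1.6-fold higher number (0.20 log units; within the scatter) from compound 1 to compound 2 and a 2.6-fold lower number (0.42 log units; beyond the scatter) from compound 3 to compound 4, 4.2-fold (0.62 log units) apart, beyond the scatter of two such steps With only one pair on each core, and with the step on the core of compound 1 lying within the scatter, this does not show that the change acts in opposite directions on the two cores, nor does it give any reason for the gap between the steps.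

The compounds shown leave open whether a longer chain in place of the neopentyl, on a saturated chain carbon bound to a carbonyl carbon and an oxygen on a saturated carbon, would also give different steps on the two cores. They also leave open whether a chain bearing an amine or a carboxylic acid at that place would follow either core's step in this assay, or neither.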